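A few compounds are considered here, and "the series" means these few. Any claim that something is new, unique, unknown or untested is made for them only; others in the source may bear on it.

Compound 3, `CNC(=O)c1cc(C(=O)N[C@H]2CC[C@H](O)CC2)c([C@@H](C)c2cccc(Cl)c2)o1`, was measured in an ADME assay on blood (Homo sapiens) for protein binding, read by LC-MS, using equilibrium dialysis (on this read-out higher numbers stand for a larger free fraction and lower numbers for a smaller free fraction), and gives 0.14. Two related compounds were measured alongside it. Compound 2, `CNC(=O)c1cc(C(=O)N[C@H]2[C@@H]3C[C@@H](O)C[C@@H]32)n([C@@H](C)c2cccc(Cl)c2)n1`, gives 0.2 in this assay, and compound 1, `CNC(=O)c1cc(C(=O)N[C@H]2[C@@H]3COC[C@@H]32)c([C@@H](C)c2ccccc2)o1`, gives 0.26 in this assay. The number for compound 3 sits within the usual scatter of both of these, so nothing sets the three apart from one another on this read-out.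

Compound 4, `CNC(=O)c1cc(C(=O)N[C@H]2CC[C@H](O)CC2)c([C@@H](C)c2ccccc2)o1`, has not yet been measured in this assay. It differs from compound 3 in one place: hydrogen in place of chloro on an aromatic carbon. Of the three measured compounds, only compound 1 carries the phenyl without chloro, and compound 1 gives 0.26 in this assay; this is the only hint available, and it rests on a single compound whose remaining structure also differs from compound 4.

The step is expected to be small, with a modestly larger unbound fraction for compound 4, a 1.6-fold higher number from compound 3 to compound 4 (0.20 log units; within the scatter), though a change within the scatter would not be surprising. The estimate for compound 4 in this assay is 0.22, with a range from 0.14 to 0.35.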

Compound 4, unbound fraction in the Homo sapiens assay: 0.33
Compound 4: middle estimate off by 1.5-fold (0.18 log units), on the low side, and the stated range covers the measured number.
By their numbers in the Homo sapiens assay, from the lowest: compounds 3, 2, 1 and 4 (each within the scatter of the next, the first and the last beyond it).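

Hydrogen in place of chloro gives the first step at this position in the Homo sapiens assay, a 2.4-fold higher number from compound 3 to compound 4 (0.37 log units; beyond the scatter), so the 3-chlorophenyl to phenyl change separates two compounds on this read-out where the earlier numbers separated none. Exchanging the group on the amide-type nitrogen instead gives a 1.3-fold higher number from compound 1 to compound 4 (0.10 log units; within the scatter), so that exchange cannot be told apart from repeat measurement. In a physicochemical assay for solubility, read by HPLC, in simulated intestinal fluid, with a stated time of 16 h, at pH 6.5 (on this read-out lower numbers stand for lower solubility and higher numbers for higher solubility), compound 3 gives 408 ug/mL and compound 4 gives 827 ug/mL, a 2.0-fold higher number from compound 3 to compound 4 (0.31 log units; beyond the scatter), so in this pair both read-outs take higher numbers with the same change.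

Going by these compounds, whether a fluoro, methyl or methoxy group at this place would read closer to chloro or to hydrogen remains open. This single pair also leaves open whether the step carries over to the core of compound 2.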